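The source may hold more compounds than are shown below. What is called first, only, known or untested is meant among the compounds shown, and "the series" means these compounds.

Measured compounds in a functional assay on SK-MEL cells (Homo sapiens) for cytotoxicity, read by MTT assay, with a stated time of 6 days; on this read-out higher numbers stand for an effect only at larger amounts of compound and lower numbers for an effect already at smaller amounts:
compound 1, `COC(=O)c1c(-c2ccc([N+](=O)[O-])cc2)oc2ccccc2c1=O`: compound 1 gives > 25 ug/mL, a limit of the assay.
compound 2, `COC(=O)c1c(-c2ccc(O)cc2)oc2ccccc2c1=O`: compound 2 gives > 25 ug/mL, a limit of the assay.
compound 3, `COc1ccc2oc(-c3ccc([N+](=O)[O-])cc3)c(C(=O)O)c(=O)c2c1`: compound 3 gives > 25 ug/mL, a limit of the assay.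

Compound 1 and compound 2 share one core and differ by hydroxy in place of nitro on an aromatic carbon. In this assay that change gives a step that the two limits leave unreadable from compound 1 to compound 2, since both values sit at the limit of > 25 ug/mL in this assay, at which 3 of the 3 values shown sit. Compound 3 carries a different core; the difference between the core of compound 1 and the core of compound 3 is not broken down here.

Compound 4, `COc1ccc2oc(-c3ccc(O)cc3)c(C(=O)O)c(=O)c2c1`, is still to be measured in this assay. It differs from compound 3 by hydroxy in place of nitro on an aromatic carbon. The place line is word for word the same as for the step from compound 1 to compound 2, so this is the same change made on the second core.

All three measured values sit at the limit of > 25 ug/mL in this assay, at which 3 of the 3 values shown sit, so nothing shows a readable effect of the change. The step from compound 3 to compound 4 is therefore expected to be about a step that the limit leaves unreadable from compound 3 to compound 4. Compound 4 is expected at 40 ug/mL, with a likely range from 20 ug/mL to 120 ug/mL, and most probably reported only as a limit again.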

Compound 4, concentration for half-maximal effect: > 25 ug/mL
Compound 4 gave a limit, no number; the forecaster's own chance of this, stated with the estimate: 80%; the middle value is on the limit's open side.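

In this assay compound 4 gives > 25 ug/mL, a limit of the assay and not a number, so no step can be read from compound 3 to compound 4, nor from compound 1 to compound 2. All the values shown coincide: the limit of > 25 ug/mL in this assay, at which 4 of the 4 values shown sit.

The compounds shown leave open whether hydroxy in place of nitro on an aromatic carbon has any effect on either core.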